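A few compounds are considered here, and "the series" means these few. Any claim that something is new, unique, unknown or untested is made for them only; others in the source may bear on it.

Measured compounds in a functional assay on A375P cells (Homo sapiens) for antiproliferative activity, read by MTT assay, with a stated time of 48 h; on this read-out higher numbers stand for weaker inhibition and lower numbers for stronger inhibition:

Compound 1 `COc1cc(-c2nn(-c3ccc(NC(=O)Nc4cccc(Cl)c4Cl)cc3)cc2-c2ccncc2)ccc1Cl` gives > 20000 nM, a limit of the assay.
Compound 2 `COc1cc(-c2nn(-c3ccc(NC(=O)Nc4ccc(Cl)c(Cl)c4)cc3)cc2-c2ccncc2)ccc1Cl` gives > 20000 nM, likewise a limit of the assay.
Compound 3 `O=C(Nc1ccc(-n2cc(-c3ccncc3)c(-c3ccc(Cl)c(O)c3)n2)cc1)Nc1ccc(Cl)c(Cl)c1` gives 13500 nM.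

Within the data shown here, compound 3 thus holds the only number in this assay; the other two entries sit at the limit of > 20000 nM in this assay, at which 2 of the 3 values shown sit. The step from compound 2 to compound 3 reads an at least 1.4-fold lower number from compound 2 to compound 3 (0.17 log units; that floor lies within the scatter), a floor that stays within the usual scatter, and the step from compound 1 to compound 2 reads a step that the two limits leave unreadable from compound 1 to compound 2.

Compound 4 `O=C(Nc1ccc(-n2cc(-c3ccncc3)c(-c3ccc(Cl)c(O)c3)n2)cc1)c1cc(Cl)cc(Cl)c1` is not yet measured. It differs from compound 3 by 3,5-dichlorophenyl in place of (3,4-dichlorophenyl)amino on a carbonyl carbon. Among the measured compounds shown here, no measured step touches the carbonyl carbon or the amide-type nitrogen; the two steps that are known concern the dichloro pattern of the outer ring and the methyl on the oxygen, and neither gave a readable change beyond the scatter. Nothing in the measured set therefore supports an expectation of a large step in this assay in either direction for compound 4.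

Compound 4 is expected to stay near compound 3, an estimated step of a 1.1-fold higher number from compound 3 to compound 4 (0.05 log units; within the scatter), with a fair chance that this assay again reports only a limit.

The estimate for compound 4 is 15000 nM, in the range 4000 nM to 60000 nM.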

Compound 4, half-maximal inhibitory concentration: 6800 nM
Estimate against measurement, compound 4: 2.2-fold (0.34 log units) above, within the range that was stated.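

In this assay, among these compounds, 3,5-dichlorophenyl in place of (3,4-dichlorophenyl)amino on a carbonyl carbon gives a 2.0-fold lower number from compound 3 to compound 4 (0.30 log units; within the scatter) and is the first step with a number at both ends. This position therefore takes a swap in which the group that leaves carries 1 hydrogen-bond donor and the group that enters carries 0, with no readable change in this read-out. The earlier steps shown here each rest on a limit of the assay and gave no such reading, and the series still leans heavily on that limit: the limit of > 20000 nM in this assay, at which 2 of the 4 values shown sit.

The swap changes two things at once, the amino nitrogen and the chlorine pattern, so the compounds shown cannot separate the two, and a 3,4-dichlorophenyl placed directly on the carbonyl carbon would be needed to do so. Also open, as far as these compounds go, is how this position responds to groups of another kind, such as a piperidine amine, a carboxylic acid or a longer alkyl chain on the carbonyl carbon, since both groups seen here are dichlorinated aromatic rings.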